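Pyrazoline sulfonamides: aryl versus styryl at the saturated carbon

The source may report more compounds than this note shows. Statements on the series, on what has been measured and on what is new or still open speak of the compounds shown alone.

Measured so far in a functional assay on HCC 2998 cells (Homo sapiens) for antiproliferative activity, with a stated time of 48 h; a lower number here means a stronger inhibitor of growth, a higher number a weaker inhibitor of growth:
- compound 1 `Cc1cc(O)c(C2=NN(c3ccc(S(N)(=O)=O)cc3)C(c3ccccc3O)C2)cc1Cl`: 2130 nM
- compound 2 `Cc1cc(O)c(C2=NN(c3ccc(S(N)(=O)=O)cc3)C(/C=C/c3ccccc3)C2)cc1Cl`: 9890 nM

Compound 2 holds the higher of the two numbers in this assay; its nearest neighbour is compound 1, reached by a 4.6-fold higher number from compound 1 to compound 2 (0.67 log units; beyond the scatter).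

Compound 3 `COc1ccc(C2CC(c3cc(Cl)c(C)cc3O)=NN2c2ccc(S(N)(=O)=O)cc2)cc1OC` differs from compound 2 in one place: 3,4-dimethoxyphenyl in place of 2-phenylethenyl on a saturated ring carbon. Among the compounds with values here, the only step with a bearing on it is the one from compound 1 to compound 2, where replacing an aryl group on the saturated ring carbon by 2-phenylethenyl raised the number beyond the scatter. Compound 3 reverses that pattern by returning an aryl group to the same carbon, although a 3,4-dimethoxyphenyl rather than the 2-hydroxyphenyl of compound 1, so a full return to the number of compound 1 is not certain. A lower number than compound 2 is expected, of the size a 3.1-fold lower number from compound 2 to compound 3 (0.49 log units; beyond the scatter), because a 4.6-fold higher number from compound 1 to compound 2 (0.67 log units; beyond the scatter) went the other way. For compound 3 the estimate in this assay is 3200 nM, with a range from 1000 nM to 12000 nM.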

Compound 3, concentration for 50% growth inhibition: 2720 nM
For compound 3 the middle estimate is 1.2-fold (0.07 log units) above the measured one; the range from low to high includes it.
By their numbers in this assay, from the lowest: compounds 1 and 3 (each within the scatter of the next); then compound 2.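

In this assay, moving from 2-phenylethenyl to 3,4-dimethoxyphenyl on the saturated ring carbon gives a 3.6-fold lower number from compound 2 to compound 3 (0.56 log units; beyond the scatter), while exchanging one aryl group for the other gives a 1.3-fold higher number from compound 1 to compound 3 (0.11 log units; within the scatter). The 2-hydroxyphenyl of compound 1 is therefore not required for a number in this range, and among these three compounds 2-phenylethenyl alone stands apart from the two substituted phenyl groups, with no compound going against this. Nothing available explains the difference between the aryl groups and 2-phenylethenyl.

Still open, from the compounds shown here alone, is whether the double bond matters, which a saturated 2-phenylethyl chain on the same carbon would address. Also open, going by these compounds, is how an unsubstituted phenyl, a single methoxy group or a dimethylamino group on the phenyl ring would compare.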